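The source may report more compounds than this note shows. Statements on the series, on what has been measured and on what is new or still open speak of the compounds shown alone.

Going by the values given here, compound 1 `O=C1O[C@H]([C@@H](O)Cn2cc(-c3ccc(Br)cc3)nn2)C(OCc2ccccc2)=C1OCc1ccccc1` is the only member of this small set with a measured number. In a functional assay on SW-620 cells (Homo sapiens) for antiproliferative activity, read by MTT assay, with a stated time of 72 h (a lower number here means a stronger inhibitor, a higher number a weaker inhibitor), compound 1 gives 3760 nM. Compound 2 `CCCCCc1ccc(-c2cn(C/C=C3\OC(=O)C(OCc4ccccc4)=C3OCc3ccccc3)nn2)cc1` reaches only the limit of this assay, at > 100000 nM. Compound 3 `CC(C)(C)OC(=O)N1CCN(C(=S)SCc2cn(C[C@H](O)[C@H]3OC(=O)C(OCc4ccccc4)=C3OCc3ccccc3)nn2)CC1` likewise reaches only the limit, at > 100000 nM. So compound 1 stands alone on the scale, while the remaining values are the limit of > 100000 nM in this assay, at which 2 of the 3 values shown sit. Compound 4 `Cc1ccc(-c2cn(C[C@H](O)[C@H]3OC(=O)C(OCc4ccccc4)=C3OCc3ccccc3)nn2)cc1` keeps the core of compound 1 and alters a single substituent: methyl in place of bromo on an aromatic carbon. Among the compounds with values here, no measured pair here shows this exchange, so there is no measured step to lean on. Such a swap of one small group for another is expected to shift this assay little, within the scatter or a modest loss. For compound 4 the expected value in this assay is 5500 nM, with a range from 1800 nM to 18000 nM. The expected step is a 1.5-fold higher number from compound 1 to compound 4 (0.17 log units; within the scatter).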

Compound 4, half-maximal inhibitory concentration: > 100000 nM
Compound 4: no number, only a limit (the forecaster's own chance of this, stated with the estimate: 10%); middle value at least 18-fold (1.25 log units) away from the limit.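

Bromo to methyl at this place is not the small swap it looks like, even though one heavy atom replaces another with no change in hydrogen-bond donors, acceptors or net charge: the result is an at least 26-fold higher number from compound 1 to compound 4 (1.42 log units; beyond the scatter). Compound 4 gives only a limit, not a number, and joins most of the set there: the limit of > 100000 nM in this assay, at which 3 of the 4 values shown sit.

The compounds shown leave open how other groups at this place, such as chloro, methoxy or an amine, would behave. They also leave open whether the measurable activity of compound 1 depends on bromo alone.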